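Replacing phenyl with methoxymethyl on the amide carbonyl

This account rests on a few compounds, and the source may have more. Where it says the series, first, only, none or still open, it means among the compounds named here.

In a functional assay on A549 cells (Homo sapiens) for antiproliferative activity, read by sulforhodamine B assay, with a stated time of 3 days (on this read-out higher numbers stand for weaker inhibition of growth and lower numbers for stronger inhibition of growth), compound 1 `COc1ccc(NC(=O)c2cccc(Nc3ncc(F)c(Nc4ccc(F)cc4)n3)c2)cc1` gives 11000 nM, while compound 2 `O=C(Nc1cccc(Nc2ncc(F)c(Nc3ccc(F)cc3)n2)c1)c1ccccc1` gives 37800 nM, the higher of the two numbers and so the weaker growth inhibition. Compound 3 `COCC(=O)Nc1cccc(Nc2ncc(F)c(Nc3ccc(F)cc3)n2)c1` keeps the core of compound 2 but carries methoxymethyl in place of phenyl on a carbonyl carbon. For the measured compounds named here, only one measured step offers any guide: a 3.4-fold higher number from compound 1 to compound 2 (0.54 log units; beyond the scatter). That modest step, beyond the scatter, comes from benzamido in place of (4-methoxyphenyl)carbamoyl on an aromatic carbon, which is a different exchange from the one at issue here. Going by the values given here, no measured compound carries a ringless group on this carbonyl carbon, so the direction remains open and no step beyond the scatter is expected in this assay. The estimated change is a 1.3-fold lower number from compound 2 to compound 3 (0.10 log units; within the scatter). For compound 3 the expected value is 30000 nM, with an estimated range of 10000 nM to 90000 nM.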

Compound 3, concentration for 50% growth inhibition: 2050 nM
Estimate against measurement, compound 3: 15-fold (1.17 log units) above; the measured number lies below the stated range.
By their numbers in this assay, from the lowest: compound 3; then compound 1; then compound 2.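

In this assay, for the compounds shown here, the group on this amide carbonyl carbon proves far more influential than the earlier compounds suggested: methoxymethyl in place of phenyl gives an 18-fold lower number from compound 2 to compound 3 (1.27 log units; beyond the scatter). An aromatic ring on this carbonyl carbon is therefore not required for growth inhibition in this small set. The exchange of (4-methoxyphenyl)carbamoyl for ((methoxymethyl)carbonyl)amino on an aromatic carbon gives a 5.4-fold lower number from compound 1 to compound 3 (0.73 log units; beyond the scatter), which makes compound 3 the strongest growth inhibitor of the three. Nothing available here accounts for this gain.

On these data alone, it remains open whether the gain depends on the oxygen of methoxymethyl or only on the loss of the phenyl ring, a question that an ethyl group in its place could address. As far as these compounds go, how a longer ether chain or an aminomethyl group would fare on this carbonyl carbon is also open.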